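Replacing the chloro group of compound 3

This account rests on a few compounds, and the source may have more. Where it says the series, first, only, none or still open, it means among the compounds named here.

In a functional assay on PC-3 cells (Homo sapiens) for antiproliferative activity, read by MTT assay, with a stated time of 96 h (on this read-out lower numbers stand for stronger inhibition and higher numbers for weaker inhibition), compound 3 `FC(F)(F)Oc1cccc(Nc2nnnc3ccc(Cl)nc23)c1` gives 5990 nM, within the scatter of compound 1 `FC(F)(F)Oc1cccc(Nc2nnnc3ccc(N4CCNCC4)nc23)c1` at 11500 nM and clearly lower than compound 2 `CCN1CCN(c2ccc3nnnc(Nc4cccc(OC(F)(F)F)c4)c3n2)CC1` at 16900 nM. Compound 4 `FC(F)(F)Oc1cccc(Nc2nnnc3ccc(NCC4CCNCC4)nc23)c1` carries ((piperidin-4-yl)methyl)amino in place of chloro on an aromatic carbon. Two measured swaps involve that same carbon. Chloro replacing piperazin-1-yl gave a 1.9-fold lower number from compound 1 to compound 3 (0.28 log units; within the scatter), and chloro replacing 4-ethylpiperazin-1-yl gave a 2.8-fold lower number from compound 2 to compound 3 (0.45 log units; beyond the scatter). Adding ethyl on the ring nitrogen gave only a 1.5-fold higher number from compound 1 to compound 2 (0.17 log units; within the scatter). Read in reverse, the two chloro swaps lead to the expectation of a modest rise in this assay. The expected change is a 1.8-fold higher number from compound 3 to compound 4 (0.26 log units; within the scatter). For compound 4, the estimated value is 11000 nM, within a range from 4000 nM to 30000 nM.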

Compound 4, half-maximal inhibitory concentration: 8320 nM
Compound 4: middle estimate off by 1.3-fold (0.12 log units), on the high side; the range from low to high includes it.
By their numbers in this assay, from the lowest: compounds 3, 4, 1 and 2 (each within the scatter of the next, the first and the last beyond it).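

The position tolerates a far bigger group: in this assay, ((piperidin-4-yl)methyl)amino, with its non-aromatic ring and hydrogen-bond donors, replaces chloro with a difference inside the scatter (a 1.4-fold higher number from compound 3 to compound 4 (0.14 log units; within the scatter)). Against piperazin-1-yl the same group also stays within the scatter (a 1.4-fold lower number from compound 1 to compound 4 (0.14 log units; within the scatter)), while against 4-ethylpiperazin-1-yl it goes just beyond it (a 2.0-fold lower number from compound 2 to compound 4 (0.31 log units; beyond the scatter)). All these numbers remain close together, so no group here stands out. Nothing measured explains these steps. As far as these compounds go, how a morpholine ring or a carboxylic acid on this carbon would compare remains open.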